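The compounds below may be only part of what the source reports. "The series", "measured", "known", "first", "only" and "open" are said of these compounds alone.

In a functional assay on HCT-116 cells (Homo sapiens) for inhibition, read by CCK-8 assay, with a stated time of 72 h, tested at 2 uM (on this read-out higher numbers stand for more inhibition of growth at the one concentration tested and lower numbers for less inhibition of growth), compound 1 (`COc1ccc(SCc2ccc(C(=O)Nc3ccccc3N)cc2)cc1`) gives 73.3% and so holds the higher of the two numbers at hand. Compound 2 (`CC(C)(C)c1ccc(SCc2ccc(C(=O)Nc3ccccc3N)cc2)cc1`) gives 4.81% with tert-butyl in place of methoxy on an aromatic carbon. Going by the values given here, this is the only measured step, a number 68.5 percentage points lower from compound 1 to compound 2 (beyond the scatter) and thus large. Compound 3 (`COc1ccc(SCc2ccc(C(=O)Nc3ccccc3N)cc2)cc1OC`) keeps the core of compound 1 and differs from it in one place, described by methoxy in place of hydrogen on an aromatic carbon as its structural change. The new methoxy stands ortho to a methoxy group and meta to a large group. The measured step bears on this only indirectly, since it replaces the methoxy group of compound 1 while compound 3 retains that group and adds a second one. Since compound 2 reaches only 4.81% after a single change on the same aromatic ring, some loss seems more likely than a gain, though probably a smaller one. The expected change is a number 23.3 percentage points lower from compound 1 to compound 3 (beyond the scatter) as a moderate estimate with wide uncertainty. The estimated value for compound 3 is 50% with an expected range from 20% to 80% in this assay once measured.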

Compound 3, percent growth inhibition at one concentration: 33.6%
Estimate against measurement, compound 3: 16.4 percentage points above; the range from low to high includes it.
By their numbers in this assay, from the lowest: compound 2; then compound 3; then compound 1.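

In this assay, methoxy in place of hydrogen at this ring carbon, ortho to a methoxy group and meta to a large group, gives a number 39.7 percentage points lower from compound 1 to compound 3 (beyond the scatter), so growth inhibition at this position is sensitive to the added group. The earlier step replaced the existing methoxy group, whereas this one leaves that group in place and changes only a carbon that had carried hydrogen, so the read-out responds to a second place on the same ring as well. Nothing at hand accounts for this loss, and the data give no explanation of it.

The compounds shown leave open whether the loss belongs to methoxy itself or would follow from any substituent at this ring carbon, a question that a fluorine atom, a hydroxyl group or an amine in the same place could address. They also leave open whether a second methoxy group at another carbon of the ring would give a similar loss, or whether the position of the added group decides the outcome.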